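Moving a Chlorine: From Compound 2 to Compound 3

The source may report more compounds than this note shows. Statements on the series, on what has been measured and on what is new or still open speak of the compounds shown alone.

Among the measured compounds shown here, in a functional assay on HepG2 cells (Homo sapiens) for antiproliferative activity, read by MTT assay, with a stated time of 48 h (on this read-out higher numbers stand for weaker inhibition and lower numbers for stronger inhibition), compound 2 `O=C(/C=C/c1ccccc1)Nc1cc2c(Nc3ccc(Cl)c(Cl)c3)ncnc2s1` gives 30100 nM, the lower of only two numbers and within the scatter of the other; compound 1 `C#Cc1cccc(Nc2ncnc3sc(NC(=O)/C=C/c4ccccc4)cc23)c1` gives 58100 nM. For the measured compounds named here, the sole measured step, a 1.9-fold lower number from compound 1 to compound 2 (0.29 log units; within the scatter), exchanged one group on a nitrogen on an aromatic ring for another and moved the number by less than the scatter. Compound 3 `O=C(/C=C/c1ccccc1)Nc1cc2c(Nc3cc(Cl)cc(Cl)c3)ncnc2s1` has not been measured; it differs from compound 2 in one place: 3,5-dichlorophenyl in place of 3,4-dichlorophenyl on a nitrogen on an aromatic ring. Going by the values given here, no measured step exchanges 3,4-dichlorophenyl for 3,5-dichlorophenyl, so the only step that bears on it is the indirect one at the same place, a 1.9-fold lower number from compound 1 to compound 2 (0.29 log units; within the scatter), which stayed within the scatter. On that basis the expected step is a 1.0-fold lower number from compound 2 to compound 3 (0.00 log units; within the scatter), that is, nothing beyond the scatter. Compound 3 is therefore estimated at 30000 nM, within a range of 10000 nM to 90000 nM.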

Compound 3, half-maximal inhibitory concentration: 21800 nM
Compound 3: the middle estimate sits 1.4-fold (0.14 log units) above what was measured, within the range that was stated.
By their numbers in this assay, from the lowest: compounds 3, 2 and 1 (each within the scatter of the next, the first and the last beyond it).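

Moving one chlorine, with 3,5-dichlorophenyl in place of 3,4-dichlorophenyl on a nitrogen on an aromatic ring, gives a 1.4-fold lower number from compound 2 to compound 3 (0.14 log units; within the scatter) in this assay, so this assay does not tell these two dichlorophenyl groups apart. Among the compounds shown here, with 3,5-dichlorophenyl in place of 3-ethynylphenyl, the result is a 2.7-fold lower number from compound 1 to compound 3 (0.43 log units; beyond the scatter), the first step at this place to pass beyond the scatter, though only modestly, whereas 3,4-dichlorophenyl stayed within it. Nothing at hand speaks to the reason for these numbers.

Still open, going by these compounds, is whether a single chlorine, a fluorine or a methoxy group on the phenyl ring would shift the number beyond the scatter. On these data alone, it is equally open whether a pyridine in place of the phenyl ring, or a longer chain in place of the phenyl-bearing amide, would do so.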